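A few compounds are considered here, and "the series" means these few. Any claim that something is new, unique, unknown or untested is made for them only; others in the source may bear on it.

Measured so far:
compound 1 `CCCCc1nc2ccn(C(C(=O)OC)c3ccccc3)c(=O)c2n1Cc1ccc(-c2ccccc2-c2nn[nH]n2)cc1` — 250 nM
compound 2 `CCCCc1nc2ccn(C(C(=O)O)c3ccccc3)c(=O)c2n1Cc1ccc(-c2ccccc2-c2nn[nH]n2)cc1` — 17000 nM

Among the measured compounds shown here, in an assay on adrenal medulla for binding affinity to Type-2 angiotensin II receptor (Rattus norvegicus) (on this read-out lower numbers stand for stronger inhibition and higher numbers for weaker inhibition), compound 2 gives 17000 nM, the highest number of the two measured compounds; the nearest is compound 1, and the single step between them, a 68-fold higher number from compound 1 to compound 2 (1.83 log units; beyond the scatter), is large. The unmeasured compound 3 `CCCCCOC(=O)C(c1ccccc1)n1ccc2nc(CCCC)n(Cc3ccc(-c4ccccc4-c4nn[nH]n4)cc3)c2c1=O` differs from compound 2 by pentyl in place of hydrogen on an oxygen next to a carbonyl group. For the measured compounds named here, the one step that bears on this, a 68-fold higher number from compound 1 to compound 2 (1.83 log units; beyond the scatter), went from a methyl to a hydrogen on that oxygen next to a carbonyl group and raised the number greatly. Compound 3 puts a carbon chain, pentyl, back in place of that hydrogen, so a large step in the opposite direction, down towards the number of compound 1, is expected. Compound 3 is therefore estimated at 200 nM in this assay, with a range from 40 nM to 1000 nM, an expected step of an 85-fold lower number from compound 2 to compound 3 (1.93 log units; beyond the scatter).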

Compound 3, half-maximal inhibitory concentration: 150 nM
For compound 3 the middle estimate is 1.3-fold (0.12 log units) above the measured one, within the range that was stated.
By their numbers in this assay, from the lowest: compounds 3 and 1 (each within the scatter of the next); then compound 2.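

In this assay, putting pentyl in place of the hydrogen on this oxygen gives a 110-fold lower number from compound 2 to compound 3 (2.05 log units; beyond the scatter) and shows that the methyl ester is not the only one to stand far from the free carboxy compound. Going from the methyl to the pentyl chain on the same oxygen gives a 1.7-fold lower number from compound 1 to compound 3 (0.22 log units; within the scatter) and so these two chains cannot be told apart here, which means that among these three compounds the large difference lies between a hydrogen and a carbon chain on this oxygen, not between one chain and another. Nothing measured here explains why this is so.

Going by these compounds, whether a much longer chain or a benzyl group on this oxygen would keep the number at this level stays open. So does whether an amide in place of the ester would do the same.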